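Replacing bromo with cyano in compound 2

The source may report more compounds than this note shows. Statements on the series, on what has been measured and on what is new or still open speak of the compounds shown alone.

Compound 1 `N#Cc1c(N)cccc1S(=O)(=O)c1ccccc1`: > 5000 nM, a limit
Compound 2 `N#Cc1c(N)cccc1S(=O)(=O)c1ccc(Br)cc1`: > 200000 nM, a limit

Both compounds were tested in a functional assay on MT4 cells (Homo sapiens) for cytotoxicity; a higher number here means a weaker inhibitor, a lower number a stronger inhibitor. Compound 2 stands at > 200000 nM, which is a limit and not a number. Compound 1 is also known only through a limit, > 5000 nM.

The next compound is compound 3 `N#Cc1ccc(S(=O)(=O)c2cccc(N)c2C#N)cc1`, which carries cyano in place of bromo on an aromatic carbon, para to a large group: cyano in place of bromo on an aromatic carbon.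

For the measured compounds named here, only one measured step bears on this change: a step that the two limits leave unreadable from compound 1 to compound 2. It concerns the same aromatic carbon, but it has no readable size to carry over. The closest reference is therefore (the limit of > 200000 nM in this assay, at which 1 of the 2 values shown sits). With no measured size to build on, no step beyond the usual scatter is expected in this assay, and no direction can be favoured. The expected step is an at least 1.6-fold lower number from compound 2 to compound 3 (0.22 log units; that floor lies within the scatter). For compound 3 the estimated value is 120000 nM, with an expected range from 10000 nM to 300000 nM.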

Compound 3, half-maximal inhibitory concentration: > 200000 nM
Compound 3 was reported as a limit; the forecaster's own chance of this, stated with the estimate: 75%; at least 1.6-fold (0.22 log units) between middle value and limit.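

In this assay, compound 3 gives > 200000 nM, which is a limit and not a number. Compound 1, compound 2 and compound 3 are all known only through limits, so the steps among them cannot be read. The compounds shown leave open how much hydrogen, bromo and cyano on this aromatic carbon differ in this read-out.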